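Swapping Furan-2-yl for Ethynyl on a Shared Core

A few compounds are considered here, and "the series" means these few. Any claim that something is new, unique, unknown or untested is made for them only; others in the source may bear on it.

- compound 1 `CSc1ncnc2c1c(-c1ccccc1)cn2[C@@H]1O[C@H](CO)[C@@H](O)[C@H]1O`: > 20000 nM (a limit)
- compound 2 `CNc1ncnc2c1c(-c1ccco1)cn2[C@@H]1O[C@H](CO)[C@@H](O)[C@H]1O`: 2570 nM

Going by the values given here, in a functional assay on A549 cells (Homo sapiens), read by MTT assay, with a stated time of 72 h (on this read-out lower numbers stand for stronger inhibition and higher numbers for weaker inhibition), compound 2 gives 2570 nM, the only actual number available. Compound 1 gives > 20000 nM, which is a limit of the assay and not a number. Compound 3 `C#Cc1cn([C@@H]2O[C@H](CO)[C@@H](O)[C@H]2O)c2ncnc(NC)c12` carries ethynyl in place of furan-2-yl on an aromatic carbon. Among the compounds with values here, no measured pair shows this swap on its own, so the expectation is uncertain. A moderate strengthening of inhibition in this assay is expected, and the estimated step is a 2.9-fold lower number from compound 2 to compound 3 (0.46 log units; beyond the scatter). For compound 3 the expected value is 900 nM, within an estimated range from 100 nM to 8000 nM.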

Compound 3, half-maximal inhibitory concentration: > 20000 nM
Compound 3 was reported as a limit (the forecaster's own chance of this, stated with the estimate: 10%); middle value at least 22-fold (1.34 log units) away from the limit.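

In this assay, putting ethynyl in place of furan-2-yl on this aromatic carbon gives an at least 7.7-fold higher number from compound 2 to compound 3 (0.89 log units; beyond the scatter). The change at this one position is therefore enough to take away the measurable inhibition seen with compound 2. Compound 3 gives only a limit, not a number, so the full size of the step cannot be read: the limit of > 20000 nM in this assay, at which 2 of the 3 values shown sit.

The compounds shown leave open whether the ring of furan-2-yl itself matters, or whether an amine or a longer carbon chain on this carbon would keep the inhibition of compound 2.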